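Ring-closing the urea side chain of a V2 agonist series

This account rests on a few compounds, and the source may have more. Where it says the series, first, only, none or still open, it means among the compounds named here.

The measured compounds are:
compound 1: `Cc1cc(C(=O)N2CCCCc3ccccc32)ccc1CNC(=O)NCC(=O)OC(C)(C)C`, 120 nM
compound 2: `Cc1cc(C(=O)N2CCCCc3ccccc32)ccc1CNC(=O)NCC(=O)N(C)C`, 58 nM

For the measured compounds named here, in a functional assay on HEK293 cells for agonist activity at Vasopressin V2 receptor (Homo sapiens), read by a luciferase reporter and cAMP accumulation (a lower number here means that less compound is needed, a higher number that more compound is needed for the effect), compound 2 gives 58 nM, the lowest of the two numbers; its nearest neighbour is compound 1, and the only measured step is a 2.1-fold lower number from compound 1 to compound 2 (0.32 log units; beyond the scatter).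

Compound 3 is `CCN(CC)C(=O)[C@@H]1CCCN1C(=O)NCc1ccc(C(=O)N2CCCCc3ccccc32)cc1C`. It differs from compound 2 in that (2-(diethylcarbamoyl)pyrrolidin-1-yl in place of ((dimethylcarbamoyl)methyl)amino on a carbonyl carbon). Going by the values given here, the one measured step, a 2.1-fold lower number from compound 1 to compound 2 (0.32 log units; beyond the scatter), concerns the group on the far carbonyl carbon and not the amino part that is replaced here, so it offers no direct guide; nothing measured reports what the loss of the hydrogen-bond donor or the five-membered ring does in this assay. The expectation is therefore for no step beyond the scatter, with wide uncertainty, which is to say a step of a 1.2-fold higher number from compound 2 to compound 3 (0.08 log units; within the scatter). For compound 3 the estimated value in this assay is 70 nM, within a range from 20 nM to 250 nM.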

Compound 3, half-maximal effective concentration: 350 nM
Compound 3: the middle estimate sits 5.0-fold (0.70 log units) below what was measured, and the stated range ends below it.
By their numbers in this assay, from the lowest: compound 2; then compound 1; then compound 3.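

In this assay the amino part on this carbonyl carbon proves sensitive to change. There is a 6.0-fold higher number from compound 2 to compound 3 (0.78 log units; beyond the scatter) and also a 2.9-fold higher number from compound 1 to compound 3 (0.46 log units; beyond the scatter) in the same direction, so the 2-(diethylcarbamoyl)pyrrolidin-1-yl group stands behind both open-chain groups, and even the tert-butoxy ester of compound 1 keeps the lower number. The replacement exchanges a chain with 1 hydrogen-bond donor for a five-membered ring with 0 donors and 1 defined stereocentre, and it turns a dimethylamide into a diethylamide, while nothing shown gives a reason for the rise.

Which of these differences carries the rise stays open. So does whether a 2-(dimethylcarbamoyl)pyrrolidin-1-yl group, a piperidine ring or the opposite stereocentre would bring the number back toward that of compound 2.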